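The source may report more compounds than this note shows. Statements on the series, on what has been measured and on what is new or still open speak of the compounds shown alone.

Compound 1 `CCOC(=O)CCCSc1nc2ccccc2n1CC(=O)O` gives 4410 nM in an assay on HEK293 cells for displacement of a labelled ligand from prostaglandin D2 receptor 2 (Homo sapiens); a lower number here means a stronger inhibitor, a higher number a weaker inhibitor.
Compound 2 `O=C(O)Cn1c(SCc2ccc(Cl)cc2)nc2ccccc21` gives 160 nM in this assay.

Among the compounds with values here, compound 2 holds the lower of the two numbers measured so far, and its only neighbour is compound 1, which sits well above it: a 28-fold lower number from compound 1 to compound 2 (1.44 log units; beyond the scatter). The next compound, compound 3 `COc1ccc(CSc2nc3ccccc3n2CC(=O)O)cc1`, is not yet measured. It differs from compound 2 in one place: methoxy in place of chloro on an aromatic carbon. Within the data shown here, only one measured step exists, and it swaps a whole chain for an aromatic ring, so it tells little about exchanging one small substituent for another on that ring. Among the measured compounds shown here, no measured pair here shows a methoxy against a chloro. With that in mind, a modest weakening is expected, a step of a 2.2-fold higher number from compound 2 to compound 3 (0.34 log units; beyond the scatter) that may stay within the scatter. Compound 3 is therefore estimated at 350 nM, with a likely range from 120 nM to 1000 nM.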

Compound 3, half-maximal inhibitory concentration: 210 nM
Compound 3: middle estimate off by 1.7-fold (0.22 log units), on the high side, within the range that was stated.
By their numbers in this assay, from the lowest: compounds 2 and 3 (each within the scatter of the next); then compound 1.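

Placing methoxy in place of chloro on this aromatic carbon, para to a large group, gives a 1.3-fold higher number from compound 2 to compound 3 (0.12 log units; within the scatter) in this assay, so the two compounds cannot be told apart by this read-out. Within the data shown here, this is the first measured exchange of one small substituent for another at this position, and it shows that here chloro and methoxy, which brings a hydrogen-bond acceptor that chloro lacks, give numbers within the scatter of each other. No available measurement bears on the reason for this match.

On these data alone, whether other groups at this position, such as an amine, a nitrile or a carboxylic acid, would give a similar number remains open. So does how the same ring would compare with plain hydrogen at this carbon, or with chloro or methoxy on another carbon of the ring.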